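The source may hold more compounds than are shown below. What is called first, only, known or untested is meant among the compounds shown, and "the series" means these compounds.

Measured so far:
compound 1 `Cc1ccc(Cn2c(CN3CCN(C(=O)C4CC4)CC3)nc3ccccc32)cc1`, 51.5%
compound 2 `Cc1cccc(Cn2c(CN3CCN(C(=O)C(C)C)CC3)nc3ccccc32)c1`, 87.2%
compound 3 `Cc1cccc(Cn2c(CN3CCN(C(=O)c4ccc(F)cc4)CC3)nc3ccccc32)c1`, 27.1%

In an assay on isolated protein for inhibition of aldehyde dehydrogenase 1A1 (Homo sapiens), read by spectrophotometry, tested at 10 uM (on this read-out lower numbers stand for less inhibition and higher numbers for more inhibition at the one concentration tested (going by the name of the read-out)), compound 1 gives 51.5%, the second highest of the three numbers; compound 3 sits lower at 27.1% and compound 2 higher at 87.2%, both gaps beyond the scatter.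

Compound 4 `O=C(C1CC1)N1CCN(Cc2nc3ccccc3n2Cc2cccc(F)c2)CC1` is unmeasured. It differs from compound 1 as follows: 3-fluorophenyl in place of 4-methylphenyl on a saturated chain carbon bound to an aromatic nitrogen.

Among the measured compounds shown here, the only single-point step in hand is a number 60.1 percentage points lower from compound 2 to compound 3 (beyond the scatter), which changes the group on the carbonyl carbon, not the group on the saturated chain carbon bound to the aromatic nitrogen, so it does not bear on this change. For the measured compounds named here, compounds 1 and 2 differ in two places at once, and their values show only that the two changes together move the number. Nothing measured speaks for a move beyond the scatter here, so no real step is expected: a number 1.5 percentage points lower from compound 1 to compound 4 (within the scatter). Compound 4 is estimated at 50%, with a range of 30% to 70%.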

Compound 4, a percentage reported as inhibition, at one concentration (the size of the read-out at that concentration, not a potency): 27.2%
Estimate against measurement, compound 4: 22.8 percentage points above; the measured number lies below the stated range.
By their numbers in this assay, from the lowest: compounds 3 and 4 (each within the scatter of the next); then compound 1; then compound 2.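

The group on a saturated chain carbon bound to an aromatic nitrogen is not a silent position in this assay: 4-methylbenzyl to 3-fluorobenzyl gives a real change (a number 24.3 percentage points lower from compound 1 to compound 4 (beyond the scatter)). The two groups match in heavy atoms, ring, hydrogen-bond counts and charge, so those counts do not separate them. No measurement available here explains the step.

Whether the identity of the substituent or its ring position carries the step stays unresolved, since both change together. An unsubstituted benzyl or a chlorobenzyl at this position would help to separate the two.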